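Toward a Pyridinyl Chalcone Sulfonylurea: Expected Brine Shrimp Toxicity

A few compounds are considered here, and "the series" means these few. Any claim that something is new, unique, unknown or untested is made for them only; others in the source may bear on it.

Measured compounds:
- compound 1 `Cc1ccc(S(=O)(=O)NC(=O)Nc2ccccc2C(=O)/C=C/c2ccc(N(C)C)cc2)cc1` — 38.1 ug/mL
- compound 2 `COc1cccc(/C=C/C(=O)c2ccccc2NC(=O)NS(=O)(=O)c2ccc(C)cc2)c1` — 23.2 ug/mL
- compound 3 `C=CCOc1ccc(/C=C/C(=O)c2ccccc2NC(=O)NS(=O)(=O)c2ccc(C)cc2)cc1` — 6.11 ug/mL

In an ADME assay on the whole organism for cytotoxicity, with Artemia salina as the target, with a stated time of 24 h (a lower number here means that less compound is needed, a higher number that more compound is needed for the effect), compound 1 gives 38.1 ug/mL, the highest number among the three measured compounds. Its closest neighbour is compound 2, with a 1.6-fold lower number from compound 1 to compound 2 (0.22 log units; within the scatter); the furthest is compound 3, with a 6.2-fold lower number from compound 1 to compound 3 (0.79 log units; beyond the scatter). Between the two others the gap is a 3.8-fold lower number from compound 2 to compound 3 (0.58 log units; beyond the scatter).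

Compound 4 `Cc1ccc(S(=O)(=O)NC(=O)Nc2ccccc2C(=O)/C=C/c2ccncc2)cc1` is not yet measured. It differs from compound 1 at one place: pyridin-4-yl in place of 4-(dimethylamino)phenyl on a double-bonded chain carbon bound to a double-bonded chain carbon. All three measured steps concern the same position, the aryl group on the double-bonded chain carbon bound to a double-bonded chain carbon, so they bear on this change, though none introduces a ring with a hetero atom. One aryl swap gave no step beyond the scatter, while the other gave a modest lowering of the number. On this basis compound 4 is expected to show at most a modest change in this assay, more likely toward a lower number than a higher one, as a 1.5-fold lower number from compound 1 to compound 4 (0.18 log units; within the scatter). The estimate for compound 4 is therefore 25 ug/mL, within the range 8 ug/mL to 70 ug/mL.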

Compound 4, concentration for half-maximal effect: 16.8 ug/mL
Beside the measured number, compound 4's estimate is 1.5-fold (0.17 log units) above it; the measured number falls inside the stated range.
By their numbers in this assay, from the lowest: compound 3; then compounds 4, 2 and 1 (each within the scatter of the next, the first and the last beyond it).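

In this assay, among these compounds, pyridin-4-yl is the first ring with a hetero atom at this place, on a double-bonded chain carbon bound to a double-bonded chain carbon, and replacing 4-(dimethylamino)phenyl with it gives a 2.3-fold lower number from compound 1 to compound 4 (0.36 log units; beyond the scatter), whereas the 3-methoxyphenyl swap gave no step beyond the scatter. Against the other two aryl groups the new ring behaves differently: the swap from 3-methoxyphenyl gives a 1.4-fold lower number from compound 2 to compound 4 (0.14 log units; within the scatter), so these two groups cannot be told apart here, while the swap from 4-(allyloxy)phenyl gives a 2.7-fold higher number from compound 3 to compound 4 (0.44 log units; beyond the scatter). A six-membered aromatic ring with a hetero atom thus falls among the carbon-only aryl groups at this position rather than outside their range, and compound 3 keeps the lowest number of the four.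

Nothing available accounts for these differences. The compounds shown leave open whether the place of the ring nitrogen matters, as pyridin-3-yl or pyridin-2-yl would show, and whether a longer chain such as butoxy or an amine on the aromatic ring would give a number closer to that of compound 3.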